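Compound 4: Swapping the Aryl Group on the Hydrazone

The compounds below may be only part of what the source reports. "The series", "measured", "known", "first", "only" and "open" are said of these compounds alone.

Of the compounds shown here, three sharing one core have been measured in a functional assay on HT-29 cells (Homo sapiens) for cytotoxicity, read by MTT assay, with a stated time of 72 h; on this read-out higher numbers stand for weaker inhibition and lower numbers for stronger inhibition. Compound 1 `COc1cc2c(Oc3ccc(NC(=O)N/N=C/c4ccc(OC(F)(F)F)cc4)cc3F)ccnc2cc1OCCCN1CCCCC1` gives 510 nM. Compound 2 `COc1ccc(/C=N/NC(=O)Nc2ccc(Oc3ccnc4cc(OCCCN5CCCCC5)c(OC)cc34)c(F)c2)c(OC)c1` gives 1600 nM. Compound 3 `COc1cc2c(Oc3ccc(NC(=O)N/N=C/c4ccc(O)cc4)cc3F)ccnc2cc1OCCCN1CCCCC1` gives 470 nM, the lowest of the three numbers, though its distance from compound 1 lies within the scatter, so those two cannot be ordered; only compound 2 stands apart, a 3.4-fold lower number from compound 2 to compound 3 (0.53 log units; beyond the scatter).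

Compound 4 `C=CCc1cccc(/C=N/NC(=O)Nc2ccc(Oc3ccnc4cc(OCCCN5CCCCC5)c(OC)cc34)c(F)c2)c1OC` has not yet been measured. It differs from compound 3 in one place: 3-allyl-2-methoxyphenyl in place of 4-hydroxyphenyl on a carbon with a double bond to nitrogen.

Among the compounds with values here, two measured steps bear on this change, both involving rings that carry methoxy groups on the carbon with a double bond to nitrogen: a 3.1-fold higher number from compound 1 to compound 2 (0.50 log units; beyond the scatter) and a 3.4-fold lower number from compound 2 to compound 3 (0.53 log units; beyond the scatter). Compound 4 brings one methoxy group back onto that ring, adds an allyl group, and removes the hydroxyl that compound 3 carries. Within the data shown here, no measured compound carries an allyl group, so its contribution is unknown. Compound 2, with 1600 nM, points toward a higher number when a methoxy-bearing ring sits at this carbon. A modest rise is therefore expected, a 2.6-fold higher number from compound 3 to compound 4 (0.41 log units; beyond the scatter). Compound 4 is estimated at 1200 nM in this assay, with a range from 400 nM to 3600 nM.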

Compound 4, half-maximal inhibitory concentration: 460 nM
Beside the measured number, compound 4's estimate is 2.6-fold (0.42 log units) above it; the range from low to high includes it.
By their numbers in this assay, from the lowest: compounds 4, 3 and 1 (each within the scatter of the next); then compound 2.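

In this assay, the position on the carbon with a double bond to nitrogen tolerates this exchange: 3-allyl-2-methoxyphenyl takes the place of 4-hydroxyphenyl with no change that can be read (a 1.0-fold lower number from compound 3 to compound 4 (0.01 log units; within the scatter)), so the hydroxyl of compound 3 is not required for a number in this range. The new ring also stands level with the 4-(trifluoromethoxy)phenyl ring (a 1.1-fold lower number from compound 1 to compound 4 (0.04 log units; within the scatter)) but apart from the 2,4-dimethoxyphenyl ring (a 3.5-fold lower number from compound 2 to compound 4 (0.54 log units; beyond the scatter)), which shows that a methoxy group on this ring does not by itself go with a higher number; among the four compounds, only compound 2 stands apart. Nothing available here accounts for the difference between the two methoxy-bearing rings.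

The compounds shown leave open what the allyl and methoxy groups each contribute, since none of them carries either group alone on this ring. On these data alone, it also remains open whether the position would accept an amine or a carboxylic acid on the ring, or a longer chain in place of the allyl group.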